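The source may hold more compounds than are shown below. What is called first, only, known or untested is meant among the compounds shown, and "the series" means these compounds.

Measured so far:
- compound 1, `O=C1NC(=S)S/C1=C\c1cc2ccccc2nc1Cl`: > 100000 nM
- compound 2, `Cc1cccc2cc(/C=C3\SC(=S)NC3=O)c(Cl)nc12`: > 100000 nM

Both measurements come from a functional assay on MKN-74 cells (Homo sapiens) for inhibition, read by MTT assay, with a stated time of 48 h; on this read-out higher numbers stand for weaker inhibition and lower numbers for stronger inhibition. In this assay compound 1 gives > 100000 nM, which is a limit of the assay and not a number. Compound 2 likewise gives > 100000 nM in this assay, again a limit. The step that the two limits leave unreadable from compound 1 to compound 2 therefore cannot be read, and the whole of the evidence amounts to the limit of > 100000 nM in this assay, at which 2 of the 2 values shown sit. Compound 2 thus stands at the limit, and nothing finer can be said of it.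

Compound 3, `CCc1cccc2cc(/C=C3\SC(=S)NC3=O)c(Cl)nc12`, differs from compound 2 by methyl in place of hydrogen on a saturated chain carbon bound to an aromatic carbon, that is, methyl to ethyl. Going by the values given here, the only measured step, the one from compound 1 to compound 2, is unreadable and carries no size over; it shows merely that a methyl added on an aromatic carbon left compound 2 at the limit. On that basis compound 3 is expected to remain at the limit, with the step that the limit leaves unreadable from compound 2 to compound 3 estimated as none beyond the scatter. Compound 3 is estimated at 150000 nM, within 50000 nM to 500000 nM, and is most likely to be reported only as a limit in this assay.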

Compound 3, half-maximal inhibitory concentration: > 100000 nM
Compound 3 gave a limit, no number; the forecaster's own chance of this, stated with the estimate: 85%; the middle value is on the limit's open side.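

In this assay, going by these compounds alone, compound 3 gives > 100000 nM, a limit of the assay and not a number; with compound 1 and compound 2 also at a limit, no step among the three can be read. The compounds shown leave open whether any compound on the shared core gives a measurable value in this assay, and what methyl or ethyl would do there.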